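Swapping a large amino group for chloro on an inactive compound

This account rests on a few compounds, and the source may have more. Where it says the series, first, only, none or still open, it means among the compounds named here.

In a functional assay on SH-SY5Y cells (Homo sapiens) for antiproliferative activity, read by MTT assay, with a stated time of 48 h (a lower number here means a stronger inhibitor of growth, a higher number a weaker inhibitor of growth), compound 1 `COc1ccc(N(C)c2ncnc3c2ncn3Cc2cc(OC)cc(OC)c2)cc1` gives > 100000 nM. This value is a limit of the assay and not a number.

Compound 2 `COc1ccc(N(C)c2ncnc3c2ncn3Cc2cc(OC)c(OC)c(OC)c2)cc1` carries one extra methoxy and gives 260 nM. Going by the values given here, that single change is the only measured step, an at least 380-fold lower number from compound 1 to compound 2 (2.58 log units; beyond the scatter), and it is large.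

Compound 3 `COc1cc(Cn2cnc3c(Cl)ncnc32)cc(OC)c1` has chloro in place of (4-methoxyphenyl)(methyl)amino on an aromatic carbon. Among the compounds with values here, it lacks the extra methoxy of compound 2, and no measured step touches the place where the chloro enters. The large step therefore offers little guidance here, and weak activity remains the likeliest outcome, possibly with only a limit again.

In this assay, the expected change is small, towards a lower number, and is estimated as an at least 1.6-fold lower number from compound 1 to compound 3 (0.22 log units; that floor lies within the scatter). For compound 3 the estimated value is 60000 nM, with an expected range from 10000 nM to 200000 nM.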

Compound 3, concentration for 50% growth inhibition: > 100000 nM
Compound 3: only a limit was reported (the forecaster's own chance of this, stated with the estimate: 55%); middle value at least 1.6-fold (0.22 log units) away from the limit.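

Compound 1 and compound 3 both give a limit of the assay and not a number, so the step between them cannot be read: the limit of > 100000 nM in this assay, at which 2 of the 3 values shown sit.

The compounds shown leave open whether chloro in place of (4-methoxyphenyl)(methyl)amino changes growth inhibition at all, and whether the extra methoxy of compound 2 would matter alongside chloro.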